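The source may report more compounds than this note shows. Statements on the series, on what has been measured and on what is new or still open speak of the compounds shown alone.

Measured compounds:
compound 1 `CCCCC(O)c1cccc(NC(=O)NC(=O)CCl)c1` — 5700 nM
compound 2 `CCCCC(O)c1cccc(NC(=O)NC(=O)CC)c1` — > 100000 nM
compound 3 `CCCCC(O)c1cccc(NC(=O)CCCCl)c1` — > 100000 nM

In a functional assay on MCF7 cells (Homo sapiens) for antiproliferative activity, with a stated time of 48 h (on this read-out lower numbers stand for stronger inhibition and higher numbers for weaker inhibition), compound 1 gives 5700 nM. Compound 2 in this assay gives > 100000 nM, which is a limit, not a number. Compound 3 likewise gives > 100000 nM, also a limit; it stands with compound 2 at the limit of > 100000 nM in this assay, at which 2 of the 3 values shown sit, so only compound 1 returns a readable value.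

The next compound, compound 4 `C=CC(=O)Nc1cccc(C(O)CCCC)c1`, differs from compound 3 by vinyl in place of 3-chloropropyl on a carbonyl carbon. Among the measured compounds shown here, two measured steps bear on this region: an at least 17-fold higher number from compound 1 to compound 2 (1.24 log units; beyond the scatter) and an at least 17-fold higher number from compound 1 to compound 3 (1.24 log units; beyond the scatter). Both leave the chloroacetyl urea of compound 1 as the only readable point, and both alternatives sit at the limit. The step that the two limits leave unreadable from compound 2 to compound 3 adds nothing readable. No measured step tests a vinyl on this carbonyl, so the direction from compound 3 cannot be read from the numbers shown.

The step of an at least 5.0-fold lower number from compound 3 to compound 4 (0.69 log units; beyond the scatter) is expected to be toward a lower number, with low confidence. Compound 4 is expected at about 20000 nM, within 3000 nM to 100000 nM.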

Compound 4, half-maximal inhibitory concentration: > 100000 nM
Compound 4 was reported as a limit (the forecaster's own chance of this, stated with the estimate: 40%); middle value at least 5.0-fold (0.69 log units) away from the limit.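

In this assay compound 4 gives > 100000 nM, which is a limit and not a number. Vinyl in place of 3-chloropropyl on this carbonyl carbon therefore yields no readable value, and the steps among compound 2, compound 3 and compound 4 cannot be read. The one readable comparison is an at least 17-fold higher number from compound 1 to compound 4 (1.24 log units; beyond the scatter), so this vinyl carbonyl joins the other two variants, and compound 1 remains the only compound in the series with a readable value: the limit of > 100000 nM in this assay, at which 3 of the 4 values shown sit.

On these data alone, the order of compound 2, compound 3 and compound 4 stays open, as all three rest at the same limit. Also open, as far as these compounds go, is whether a bromoacetyl or a 2-chloropropanoyl group on the urea of compound 1 would keep a readable value.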